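The source may hold more compounds than are shown below. What is called first, only, known or untested is meant among the compounds shown, and "the series" means these compounds.

In a functional assay on HCT-116 cells (Homo sapiens) for antiproliferative activity, read by MTT assay, with a stated time of 72 h (a lower number here means a stronger inhibitor, a higher number a weaker inhibitor), compound 1 `COc1cccc(N2C(=O)COc3ccc(-c4cnc5ccccc5c4)cc32)c1` gives 8240 nM. Compound 2 `O=C1COc2ccc(-c3cnc4ccccc4c3)cc2N1C1CCCCC1` gives > 40000 nM, which is a limit of the assay and not a number. Compound 3 `COc1ccc(N2C(=O)COc3ccc(-c4cnc5ccccc5c4)cc32)cc1` carries 4-methoxyphenyl in place of cyclohexyl on an amide-type nitrogen in a ring. Among the measured compounds shown here, the only measured step bearing on this change is an at least 4.8-fold higher number from compound 1 to compound 2 (0.68 log units; beyond the scatter), beyond the scatter, with cyclohexyl entering in place of 3-methoxyphenyl. Read in reverse, it suggests a change of similar size toward a lower number in this assay. The expected step is an at least 4.0-fold lower number from compound 2 to compound 3 (0.60 log units; beyond the scatter). Compound 3 is estimated at 10000 nM, with an expected range of 3000 nM to 35000 nM.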

Compound 3, half-maximal inhibitory concentration: > 40000 nM
Compound 3 gave a limit, no number (the forecaster's own chance of this, stated with the estimate: 15%); at least 4.0-fold (0.60 log units) between middle value and limit.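

On the amide-type nitrogen in a ring, 4-methoxyphenyl in place of 3-methoxyphenyl gives an at least 4.8-fold higher number from compound 1 to compound 3 (0.68 log units; beyond the scatter) in this assay, so an aromatic ring at this position does not by itself keep a measurable value. Compound 3 gives > 40000 nM, which is a limit of the assay and not a number. The step between compound 2 and compound 3 cannot be read, and the comparison stops at: the limit of > 40000 nM in this assay, at which 2 of the 3 values shown sit.

Open, going by these compounds, is whether 3-aminophenyl or 3-chlorophenyl on this nitrogen would keep or lower the number seen for compound 1, 8240 nM.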